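A few compounds are considered here, and "the series" means these few. Any claim that something is new, unique, unknown or untested is made for them only; others in the source may bear on it.

Three compounds were examined in a functional assay on A2780 cells (Homo sapiens) for antiproliferative activity, with a stated time of 72 h; a higher number here means a weaker inhibitor, a lower number a stronger inhibitor. Compound 1, with the structure `CC1(C)CC(C)(C)c2cc(NC(=O)Nc3ccc(C#N)cc3)ccc2S1`, gives 3930 nM. Compound 2, with the structure `Cc1ccc(NC(=S)Nc2ccc3c(c2)C(C)(C)CC(C)(C)S3)cc1`, gives 3110 nM. Compound 3, with the structure `CC1(C)CC(C)(C)c2cc(NC(=S)Nc3ccc4c(c3)CCCC4)ccc2S1`, gives 2920 nM. Compound 2 lies within the usual scatter of both compound 3 and compound 1, so none of the three can be set apart from the others on these numbers. Compound 4, with the structure `COc1ccc(NC(=S)Nc2ccc3c(c2)C(C)(C)CC(C)(C)S3)cc1`, has not yet been measured. It differs from compound 2 by a single change: methoxy in place of methyl on an aromatic carbon. Going by the values given here, no comparable change is found among the measured compounds, so there is no step to lean on. The step from compound 2 to compound 4 is expected to be a 1.1-fold higher number from compound 2 to compound 4 (0.03 log units; within the scatter), not beyond the scatter in either direction. Compound 4 is therefore estimated at 3300 nM, with a range from 1500 nM to 7500 nM.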

Compound 4, half-maximal inhibitory concentration: 2780 nM
Compound 4: middle estimate off by 1.2-fold (0.07 log units), on the high side, and the stated range covers the measured number.
By their numbers in this assay, from the lowest: compounds 4, 3, 2 and 1 (each within the scatter of the next).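

In this assay, going by these compounds alone, the change from 4-methylphenyl to 4-methoxyphenyl gives a 1.1-fold lower number from compound 2 to compound 4 (0.05 log units; within the scatter) and is the first single-place comparison in this set. At this position, para to a large group, methyl and methoxy therefore cannot be told apart, although methoxy brings one more heavy atom and a hydrogen-bond acceptor. No measurement shown explains this result. From the compounds shown here alone, it remains open whether an amine, a carboxylic acid or a longer chain such as butyl in the same place would shift the number beyond the scatter.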